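The source may hold more compounds than are shown below. What is called first, only, known or untested is meant among the compounds shown, and "the series" means these compounds.

Cytotoxicity values in an ADME assay on Huh-7 cells (Homo sapiens) for cytotoxicity, read by a luciferase reporter and WST assay, with a stated time of 3 days; a lower number here means that less compound is tolerated, a higher number that more compound is tolerated:

compound 1 `O=C(Nc1ccc(F)cc1)c1c(NO)cc(-c2ccccc2)oc1=O`: > 20000 nM.
compound 2 `O=C(Nc1ccc(Cl)cc1)c1c(NO)cc(-c2ccccc2)oc1=O`: > 20000 nM.
compound 3 `CNC(=O)c1c(NO)cc(-c2ccc(F)cc2)oc1=O`: > 20000 nM.

For compound 3 this value is a limit of the assay and not a number. The same holds for compound 1. The same holds for compound 2. The step that the two limits leave unreadable from compound 1 to compound 2 is therefore not readable in size; the change is chloro in place of fluoro on an aromatic carbon. Across the three measured compounds the picture is the limit of > 20000 nM in this assay, at which 3 of the 3 values shown sit. The difference between the core of compound 1 and the core of compound 3 is not broken down here.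

Compound 4 `CNC(=O)c1c(NO)cc(-c2ccc(Cl)cc2)oc1=O` differs from compound 3 by chloro in place of fluoro on an aromatic carbon, the same change as that from compound 1 to compound 2. Compound 4 is expected to show a step that the limit leaves unreadable from compound 3 to compound 4, resting on the unreadable step that the two limits leave unreadable from compound 1 to compound 2 and on (the limit of > 20000 nM in this assay, at which 3 of the 3 values shown sit). The estimate for compound 4 in this assay is 35000 nM, within 15000 nM to 120000 nM.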

Compound 4, half-maximal cytotoxic concentration: > 20000 nM
Compound 4: a limit, no number; the forecaster's own chance of this, stated with the estimate: 85%; the middle value does not contradict the limit.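

In this assay compound 4 gives > 20000 nM, a limit and not a number. Among these compounds, no step from compound 3 to compound 4 can be read, as both values are limits. The compounds shown leave open whether chloro in place of fluoro changes the half-maximal cytotoxic concentration at all: the limit of > 20000 nM in this assay, at which 4 of the 4 values shown sit.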